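Methyl ester to carboxylic acid: compound 3 to compound 4

The compounds below may be only part of what the source reports. "The series", "measured", "known", "first", "only" and "open" are said of these compounds alone.

In an assay on cells for antagonist activity at vitamin D3 receptor (Homo sapiens), read by a luciferase reporter (a higher number here means a weaker inhibitor, a lower number a stronger inhibitor), compound 1 `COC(=O)c1cccc(OCc2oc(-c3ccccc3OC)nc2C)c1` gives 7330 nM, compound 2 `COC(=O)c1ccc(OCc2oc(-c3ccccc3OC)nc2C)cc1` gives 17900 nM and compound 3 `COC(=O)c1ccc(OCc2oc(-c3cccc(OC)c3)nc2C)cc1` gives 8890 nM. Compound 3 holds the second highest of the three numbers; the gap to compound 1 and the gap to compound 2 both sit within the scatter, and a 2.0-fold lower number from compound 2 to compound 3 (0.30 log units; within the scatter). Compound 4 `COc1cccc(-c2nc(C)c(COc3ccc(C(=O)O)cc3)o2)c1` differs from compound 3 by hydrogen in place of methyl on an oxygen next to a carbonyl group, methoxycarbonyl to carboxy. Among the measured compounds shown here, no measured step touches this group; the single recorded step, between compound 2 and compound 3, concerns the methoxyphenyl and gives no guide here. The expectation for compound 4 is therefore a step of a 1.0-fold higher number from compound 3 to compound 4 (0.01 log units; within the scatter) in this assay, with wide uncertainty. Compound 4 is estimated at 9000 nM, between 2000 nM and 40000 nM.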

Compound 4, half-maximal inhibitory concentration: > 80000 nM
Compound 4 was reported as a limit; the forecaster's own chance of this, stated with the estimate: 15%; middle value at least 8.8-fold (0.94 log units) away from the limit.
By their numbers in this assay, from the lowest: compounds 1, 3 and 2 (each within the scatter of the next, the first and the last beyond it). At a limit, above all of these: compound 4.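

In this assay the methoxycarbonyl group responds to change: methoxycarbonyl to carboxy gives an at least 8.9-fold higher number from compound 3 to compound 4 (0.95 log units; beyond the scatter). This is the only step shown that lies beyond the scatter, whereas the methoxyphenyl change gives a 2.0-fold lower number from compound 2 to compound 3 (0.30 log units; within the scatter). The value of compound 4 is a limit, not a number: the limit of > 80000 nM in this assay, at which 1 of the 4 values shown sits.

The compounds shown leave open how an amide, a hydroxymethyl group or an ethyl ester would read at this place. They also leave open whether methoxycarbonyl to carboxy on compound 1 would give a similar step.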